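Swapping methyl for cyclopropyl on an amide nitrogen

A few compounds are considered here, and "the series" means these few. Any claim that something is new, unique, unknown or untested is made for them only; others in the source may bear on it.

Compound 1 `CNC(=O)c1cccc(CSc2cnc(Nc3ccccn3)s2)c1` gives "not determined" (no result reported)
Compound 2 `CNC(=O)c1cccc(NCc2cnc(Nc3ccccn3)s2)c1` gives "not determined" (no result reported)
Compound 3 `CNC(=O)c1ccc(F)c(NCc2cnc(Nc3ccccn3)s2)c1` gives 20 nM

In a functional assay on HUVEC cells (Homo sapiens) for antiproliferative activity (a lower number here means a stronger inhibitor, a higher number a weaker inhibitor), only compound 3 carries a number, so it stands alone and nothing measured ranks it against a neighbour. Compound 4 `O=C(NC1CC1)c1ccc(F)c(NCc2cnc(Nc3ccccn3)s2)c1` alters compound 3 in one place, with cyclopropyl in place of methyl on an amide-type nitrogen and the rest unchanged. Going by the values given here, no measured step shows how this kind of swap behaves, so the expectation is cautious: no clear shift in either direction. The expected size of the change, a 1.1-fold higher number from compound 3 to compound 4 (0.04 log units; within the scatter) in this assay, is none beyond the scatter. Compound 4 is estimated at 22 nM with an expected range from 6 nM to 80 nM for its coming measurement.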

Compound 4, half-maximal inhibitory concentration: 14 nM
Beside the measured number, compound 4's estimate is 1.6-fold (0.20 log units) above it; low and high end bracket the measured number.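

In this assay, the amide nitrogen carries cyclopropyl as well as methyl: the step is a 1.4-fold lower number from compound 3 to compound 4 (0.15 log units; within the scatter) and so gives no real separation between the two compounds. This single pair shows that a ring of three carbons can stand at this position with the number staying in the same range. Nothing measured here explains this result. Compound 1 and compound 2 carry no number, so steps involving them cannot be read. As far as these compounds go, whether a longer chain or a phenyl ring on this nitrogen would keep the number in that range remains open.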